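Swapping Methyl for Methoxy on the Benzyl Ring

A few compounds are considered here, and "the series" means these few. Any claim that something is new, unique, unknown or untested is made for them only; others in the source may bear on it.

Measured so far:
compound 1 `CN(CCCCn1c(=O)oc2ccccc21)Cc1ccccc1` — 2.6 nM
compound 2 `Cc1cccc(CN(C)CCCCn2c(=O)oc3ccccc32)c1` — 102 nM

Among the measured compounds shown here, in an assay on membranes from liver for displacement of a labelled ligand from Sigma non-opioid intracellular receptor 1 (Rattus norvegicus), read by scintillation counting (on this read-out lower numbers stand for stronger inhibition and higher numbers for weaker inhibition), compound 2 gives 102 nM, the higher of the two numbers measured so far. For the measured compounds named here, the only step reaching it is a 39-fold higher number from compound 1 to compound 2 (1.59 log units; beyond the scatter), which puts a methyl in place of hydrogen on an aromatic carbon of the benzyl ring.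

Compound 3 `COc1ccccc1CN(C)CCCCn1c(=O)oc2ccccc21` differs from compound 2 by 2-methoxyphenyl in place of 3-methylphenyl on a saturated chain carbon bound to an amine nitrogen. The methyl step is the only measured one that bears on this change. Going by the values given here, it shows that one small group on that ring can shift the number a great deal, but no methoxy compound has been measured, so the direction for compound 3 is not fixed by the data. Because compound 1 gives 2.6 nM with an unsubstituted ring, the change is expected to move the number back toward it, as a step of a 3.4-fold lower number from compound 2 to compound 3 (0.53 log units; beyond the scatter). Compound 3 is expected to give about 30 nM, within 6 nM to 150 nM.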

Compound 3, inhibition constant: 594 nM
Compound 3: the middle estimate sits 20-fold (1.30 log units) below what was measured; measured number above the stated range.
By their numbers in this assay, from the lowest: compound 1; then compound 2; then compound 3.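

Putting a methoxy group on the unsubstituted ring of compound 1 costs far more than the methyl did, with a 230-fold higher number from compound 1 to compound 3 (2.36 log units; beyond the scatter). Exchanging 3-methylphenyl for 2-methoxyphenyl also raises the number rather than lowering it, with a 5.8-fold higher number from compound 2 to compound 3 (0.77 log units; beyond the scatter), so in this assay both substituted rings lie well above the unsubstituted one, and this ring position tolerates change poorly in these three compounds. Nothing measured here gives a reason for this loss.

Going by these compounds, compound 2 and compound 3 differ in both the group and its place on the ring, so it stays open whether the higher numbers follow the group itself or where it sits. On these data alone, it is also open whether a single fluorine atom or a hydroxy group on this ring would keep the number close to that of compound 1.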